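The source may hold more compounds than are shown below. What is called first, only, known or untested is meant among the compounds shown, and "the series" means these compounds.

Working notes on the series.

The shared core is carried unchanged through compound 1 `O=C(O)c1cnc2c(F)cccc2c1`, compound 2 `CCc1cccc2cc(C(=O)O)cnc12` and compound 3 `Cc1cccc2cc(C(=O)O)cnc12`; they differ only in the group on one aromatic carbon. In a functional assay on the whole organism (strain Sprague-Dawley) for inhibition, with Rattus norvegicus as the target (on this read-out lower numbers stand for an effect already at smaller amounts and higher numbers for an effect only at larger amounts of compound), compound 1 gives 150 mg/kg. In this assay compound 2 gives 75 mg/kg, and the change from compound 1 to compound 2, ethyl in place of fluoro on an aromatic carbon, amounts to a 2.0-fold lower number from compound 1 to compound 2 (0.30 log units; within the scatter). For compound 3 this assay reports only a limit, > 25 mg/kg, so that the limit of > 25 mg/kg in this assay, at which 1 of the 3 values shown sits, marks where compound 3 stands. The steps a step that the limit leaves unreadable from compound 1 to compound 3 and a step that the limit leaves unreadable from compound 2 to compound 3 therefore cannot be sized.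

Compound 4 `O=C(O)c1cnc2c(C(F)(F)F)cccc2c1` is not yet measured. It differs from compound 3 by trifluoromethyl in place of methyl on an aromatic carbon. Within the data shown here, the only readable step in the set, from fluoro to ethyl, lay within the scatter, and the two steps that lead to compound 3 give no size. On that basis no step beyond the scatter is expected, and the estimate for compound 4 in this assay is 100 mg/kg, with a range from 40 mg/kg to 300 mg/kg, a step that the limit leaves unreadable from compound 3 to compound 4 that is expected rather than known.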

Compound 4, minimum effective dose: 75 mg/kg
Beside the measured number, compound 4's estimate is 1.3-fold (0.12 log units) above it; the measured number falls inside the stated range.
By their numbers in this assay, from the lowest: compounds 2, 4 and 1 (each within the scatter of the next).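

In this assay, trifluoromethyl in place of ethyl on this aromatic carbon gives no change at the digits printed from compound 2 to compound 4 (within the scatter), and trifluoromethyl in place of fluoro gives a 2.0-fold lower number from compound 1 to compound 4 (0.30 log units; within the scatter). Fluoro, ethyl and trifluoromethyl at this position now all stand within the scatter of one another, which the single readable step among the earlier compounds could not show. Every step involving compound 3, the new one included, cannot be read, because compound 3 is known only as a limit: the limit of > 25 mg/kg in this assay, at which 1 of the 4 values shown sits.

The compounds shown leave open whether any group on this aromatic carbon moves the number beyond the scatter, for instance an amine, a methoxy group or a longer chain such as butyl. They also leave open how this position behaves once the carboxylic acid of the shared core is replaced by an amide or a nitrile.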